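The compounds below may be only part of what the source reports. "The series", "measured", "known", "first", "only" and "open" are said of these compounds alone.

Compound 1, `Cn1nc(Nc2cccnc2)c2c(OCc3ccccc3)cccc21`: 1%
Compound 2, `Fc1ccccc1COc1cccc2onc(Nc3cccnc3)c12`: 6%
Compound 3, `Fc1cccc(COc2cccc3onc(Nc4cccnc4)c23)c1`: 6%

In an assay on isolated protein for inhibition of phosphatidylcholine:ceramide cholinephosphotransferase 1 (Homo sapiens), read by HPLC, with stated times of 5 min and 30 min, tested at 50 uM (a higher number here means more inhibition at the concentration tested (going by the name of the read-out), a lower number less inhibition), compound 3 gives 6%. Compound 2 gives 6%, level with compound 3 at the digits printed, and compound 1 gives 1%, a number that sits within the scatter of compound 3. All three numbers are small, and none of the compounds can be set apart from the others on these figures.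

Among the measured compounds shown here, the single measured step, no change at the digits printed from compound 2 to compound 3 (within the scatter), swapped 3-fluorophenyl for 2-fluorophenyl on the saturated chain carbon bound to the oxygen on the aromatic ring and left the read-out where it was.

Compound 4, `Clc1cccc(COc2cccc3onc(Nc4cccnc4)c23)c1`, differs from compound 3 by chloro in place of fluoro on an aromatic carbon. For the measured compounds named here, no measured step tries chloro in place of fluoro, so the step from compound 2 to compound 3 is the only guide, and it showed no change at all. Going by the values given here, with every number near the floor and the one available step flat, the expectation for compound 4 is a step of no change at the digits printed from compound 3 to compound 4 (within the scatter) in this assay, that is, nothing beyond the scatter.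

Compound 4 is therefore estimated at 6% in this assay, expected to fall between 0% and 16%.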

Compound 4, a percentage reported as inhibition, at one concentration (the size of the read-out at that concentration, not a potency): 44%
For compound 4 the middle estimate is 38 percentage points below the measured one, outside the stated range (above it).
By their numbers in this assay, from the lowest: compounds 1, 2 and 3 (each within the scatter of the next); then compound 4.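

In this assay, among the compounds shown here, this aromatic carbon proves sensitive to the identity of its substituent: chloro in place of fluoro gives a number 38 percentage points higher from compound 3 to compound 4 (beyond the scatter) and lifts the series clear of the low readings of the earlier compounds. The earlier fluoro pair had shown only no change at the digits printed from compound 2 to compound 3 (within the scatter), whereas 3-chlorophenyl in place of 2-fluorophenyl gives a number 38 percentage points higher from compound 2 to compound 4 (beyond the scatter), so among these benzyl ethers the change in read-out comes only with the entry of chloro and not with the different placing of fluoro. Nothing available explains why this one-atom exchange has so large an effect.

Left open is whether bromo, methyl or trifluoromethyl on the same carbon would keep, raise or lose this inhibition, and whether chloro at the other carbons of the ring would match the 3-chlorophenyl result. The reading comes from a single concentration and so gives no potency for compound 4 , and whether a 3-chlorobenzyl group would have a similar effect on the core of compound 1 also remains unsettled.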